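Aryl amide halogen variation on the shared core

The source may report more compounds than this note shows. Statements on the series, on what has been measured and on what is new or still open speak of the compounds shown alone.

Among the measured compounds shown here, compound 2 `O=C(CCC(=O)OCCCCCCSc1ccc([N+](=O)[O-])c2nonc12)Nc1ccc(Br)cc1` gives 5090 nM in an assay on isolated protein for inhibition of glutathione S-transferase P (Homo sapiens), with a stated time of 10 min (a higher number here means a weaker inhibitor, a lower number a stronger inhibitor), the lower of the two numbers known so far. For the measured compounds named here, the only neighbour is compound 1 `O=C(CCC(=O)OCCCCCCSc1ccc([N+](=O)[O-])c2nonc12)Nc1ccc(F)cc1`, which in this assay gives 8570 nM; the one measured step, a 1.7-fold lower number from compound 1 to compound 2 (0.23 log units; within the scatter), stays within the scatter, so the two compounds cannot be ordered on these numbers.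

Compound 3 `O=C(CCC(=O)OCCCCCCSc1ccc([N+](=O)[O-])c2nonc12)Nc1ccc(F)c(Cl)c1` is not yet measured. It differs from compound 2 by 3-chloro-4-fluorophenyl in place of 4-bromophenyl on an amide-type nitrogen, again an exchange of halogen substitution on the amide-bound ring. Going by the values given here, the only step that bears on it is a 1.7-fold lower number from compound 1 to compound 2 (0.23 log units; within the scatter), a halogen exchange on the same ring that did not move the number beyond the scatter. The expected step is therefore a 1.0-fold lower number from compound 2 to compound 3 (0.01 log units; within the scatter), that is, nothing beyond the scatter in either direction. Compound 3 is expected to give about 5000 nM in this assay, estimated within 2000 nM to 12000 nM.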

Compound 3, half-maximal inhibitory concentration: 9850 nM
Compound 3: the middle estimate sits 2.0-fold (0.29 log units) below what was measured; low and high end bracket the measured number.
By their numbers in this assay, from the lowest: compounds 2, 1 and 3 (each within the scatter of the next).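

In this assay, 3-chloro-4-fluorophenyl in place of 4-bromophenyl on the amide-type nitrogen gives a 1.9-fold higher number from compound 2 to compound 3 (0.29 log units; within the scatter), and chloro in place of hydrogen on an aromatic carbon gives a 1.1-fold higher number from compound 1 to compound 3 (0.06 log units; within the scatter); both steps stay within the scatter. Adding a chloro to the fluorinated ring therefore has no readable effect here, just as exchanging fluoro for bromo had none, and compounds 1, 2 and 3 cannot be ordered on these numbers. No available evidence bears on this result.

The compounds shown leave open whether this ring responds to anything other than halogens, such as a methoxy group, a nitrile or a carboxylic acid. Going by these compounds, whether an alkyl amine in place of the aniline nitrogen's aryl group, or a longer chain in the linker, would move the number also remains open.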